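Replacing 3-aminophenyl with 3-(dimethylamino)propyl on compound 2

The compounds below may be only part of what the source reports. "The series", "measured", "known", "first", "only" and "open" are said of these compounds alone.

Of the compounds shown here, three sharing a core have been tested in a functional assay on SK-BR-3 cells (Homo sapiens) for cytotoxicity, read by MTT assay, with a stated time of 72 h; on this read-out lower numbers stand for stronger inhibition and higher numbers for weaker inhibition. Compound 2 `Nc1cccc(Nc2c(C(=O)NCc3ccc(F)cc3)nc(Br)c3cccnc23)c1` returned no number, only a limit of > 10000 nM. That limit is also the top of the range seen so far, as the limit of > 10000 nM in this assay, at which 1 of the 3 values shown sits, records. Compound 1 `N[C@H]1CC[C@H](Nc2c(C(=O)NCc3ccc(F)cc3)nc(N3CCCCS3(=O)=O)c3cccnc23)CC1` gave 8500 nM, and compound 3 `CC(C)(C)OC(=O)N1CCN(c2c(C(=O)NCc3ccc(F)cc3)nc(Br)c3cccnc23)CC1` gave 3000 nM. Within the data shown here, these two differ from compound 2 in more than one place, so no measured step isolates a single change.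

Compound 4 `CN(C)CCCNc1c(C(=O)NCc2ccc(F)cc2)nc(Br)c2cccnc12` carries 3-(dimethylamino)propyl in place of 3-aminophenyl on a nitrogen on an aromatic ring. Among the measured compounds shown here, with no direct precedent, the expectation in this assay rests on the spread of the measured values, with compound 3 at 3000 nM as the closest guide. A moderate step towards stronger inhibition is expected, though a result no better than the limit remains possible. The expected step is an at least 3.3-fold lower number from compound 2 to compound 4 (0.52 log units; beyond the scatter). For compound 4 the estimated value is 3000 nM, with an expected range of 800 nM to 10000 nM.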

Compound 4, half-maximal inhibitory concentration: 1000 nM
Compound 4: middle estimate off by 3.0-fold (0.48 log units), on the high side; the range from low to high includes it.
By their numbers in this assay, from the lowest: compound 4; then compound 3; then compound 1. At a limit, above all of these: compound 2.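

In this assay, this is the only comparison shown that isolates a single change, and it gives an at least 10-fold lower number from compound 2 to compound 4 (1.00 log units; beyond the scatter). Compound 2 is held at a limit and not at a number: the limit of > 10000 nM in this assay, at which 1 of the 4 values shown sits. The step is therefore a minimum, and it shows that the group on this nitrogen on an aromatic ring affects the read-out, with the ringless 3-(dimethylamino)propyl of compound 4 giving 1000 nM where 3-aminophenyl gave no number.

This one step cannot separate the loss of the aromatic ring from the change in the amine, and it leaves open how a shorter alkyl chain, a chain ending in a primary amine, or a morpholine would read here. Among these compounds, it also leaves open whether the step would hold with a different group elsewhere on the shared core, such as the one in compound 1.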